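Swapping the carboxyphenyl group of compound 2

This account rests on a few compounds, and the source may have more. Where it says the series, first, only, none or still open, it means among the compounds named here.

Compound 1 `O=C(O)c1cc(-c2cccc(COc3ccc4c(=O)n(CC5CC5)sc4c3)c2)ccc1Cl` gives 100% in an ADME assay on a cell-free system (plasma, Rattus norvegicus) for metabolic stability, read by LC-MS, with a stated time of 1 h, at 37 degrees C, tested at 100 uM; on this read-out lower numbers stand for a less stable compound and higher numbers for a more stable compound
Compound 2 `COc1ccc(C(=O)O)cc1-c1cccc(COc2ccc3c(c2)CN(C2CCCC2)C3=O)c1` gives 100% in this assay

On these numbers, compound 2 (100%) stands level with compound 1 within the usual scatter. Compound 3 `O=C(O)c1ccc(-c2cccc(COc3ccc4c(c3)CN(C3CCCC3)C4=O)c2)c(Cl)c1` keeps the shared core of compound 2 and differs in one place 4-carboxy-2-chlorophenyl in place of 5-carboxy-2-methoxyphenyl on an aromatic carbon on an aromatic carbon of a six-membered aromatic ring of carbon only, meta to a large group. In words, 4-carboxy-2-chlorophenyl stands in place of 5-carboxy-2-methoxyphenyl. Within the data shown here, no two measured compounds differ in one place alone, so this step in this assay has no direct precedent. Among the measured compounds shown here, the only guidance comes from the two measured compounds. Compound 2 carries the methoxy group and gives 100% in this read-out, while compound 1 carries a chlorine on its carboxy-bearing ring and gives 100% there. With both at the same figure, no step beyond the scatter is expected in either direction. The estimated change is a number 3 percentage points lower from compound 2 to compound 3 (within the scatter) and stays within the scatter. Compound 3 is expected at 97% with an estimated range from 85% to 100% when measured.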

Compound 3, percent of the compound remaining: 100%
For compound 3 the middle estimate is 3 percentage points below the measured one; measured number inside the range.
By their numbers in this assay, from the lowest: compounds 1, 2 and 3 (each within the scatter of the next).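

In this assay, among these compounds, the exchange of 5-carboxy-2-methoxyphenyl for 4-carboxy-2-chlorophenyl, on an aromatic carbon meta to a large group, gives no change at the digits printed from compound 2 to compound 3 (within the scatter) and is the only step here between two compounds that differ in one place. On the shared core of these two compounds, this position therefore carries either carboxy-bearing phenyl group with the same printed stability figure, something the earlier pair could not show, since those two compounds differ in more than one place. Nothing available gives a measured reason for this result.

This single exchange alters the methoxy group, the chlorine and the place of the carboxylic acid on the ring together, so the compounds shown do not tell what each of these changes would do alone. They also leave open whether the same figure would hold with a methyl ester or an amide in place of the carboxylic acid, or with a fluorine or a methyl group in place of the chlorine.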